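Phenyl for pyridin-3-yl on the chloro analogue

A few compounds are considered here, and "the series" means these few. Any claim that something is new, unique, unknown or untested is made for them only; others in the source may bear on it.

Going by the values given here, the three measured members share one core and differ in two aromatic groups. Compound 1 `O=c1c(-c2nnc(-c3ccc(F)cc3)o2)c[nH]c2ncc(-c3cccnc3)cc12` gives 19.7% in a functional assay on HCT-116 cells (Homo sapiens) for inhibition, read by MTT assay, with a stated time of 24 h, tested at 10 uM; on this read-out lower numbers stand for less inhibition of growth and higher numbers for more inhibition of growth at the one concentration tested. Compound 2 `O=c1c(-c2nnc(-c3ccc(Cl)cc3)o2)c[nH]c2ncc(-c3cccnc3)cc12` gives 11.8% in this assay, the change being a number 7.9 percentage points lower from compound 1 to compound 2 (within the scatter). Compound 3 `CS(=O)(=O)c1ccc(-c2cnc3[nH]cc(-c4nnc(-c5ccc(F)cc5)o4)c(=O)c3c2)cc1` gives 18.7% in this assay, the change being a number 1 percentage points lower from compound 1 to compound 3 (within the scatter). Compound 2 thus carries the lowest of the three numbers, but its gaps to compound 3 and to compound 1 both lie within the scatter, so the three cannot be ordered.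

Compound 4 `O=c1c(-c2nnc(-c3ccc(Cl)cc3)o2)c[nH]c2ncc(-c3ccccc3)cc12` is not yet measured. It differs from compound 2 by phenyl in place of pyridin-3-yl on an aromatic carbon.

Among the compounds with values here, no measured step swaps pyridin-3-yl for phenyl. Within the data shown here, the only step at the same place, the exchange of pyridin-3-yl for 4-(methylsulfonyl)phenyl from compound 1 to compound 3, stayed within the scatter, as did the exchange at the other aromatic group from compound 1 to compound 2. Nothing measured therefore points to a shift beyond the scatter in this assay for compound 4, in either direction.

Compound 4 is estimated at 12% in this assay, with a range from 0% to 26%. The expected step is a number 0.2 percentage points higher from compound 2 to compound 4 (within the scatter), within the scatter.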

Compound 4, percent growth inhibition at one concentration: 21.6%
Estimate against measurement, compound 4: 9.6 percentage points below; the range from low to high includes it.
By their numbers in this assay, from the lowest: compounds 2, 3, 1 and 4 (each within the scatter of the next).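

Going by these compounds alone, the exchange of pyridin-3-yl for phenyl is the first direct look at the ring nitrogen of this group, and on the chloro compounds in this assay it reads as a number 9.8 percentage points higher from compound 2 to compound 4 (within the scatter) on this aromatic carbon. Losing that ring nitrogen, and with it the hydrogen-bond acceptor counted for pyridin-3-yl, thus brings no shift beyond the scatter, so this position has now taken two aromatic exchanges, phenyl on the chloro compounds and 4-(methylsulfonyl)phenyl on the fluoro compounds, with neither step leaving the scatter. No measured property of these compounds bears on this step, and no cause can be offered for it.

Still open, as far as these compounds go, is whether a group of another kind at this position, such as a primary amine, a carboxylic acid or a longer alkyl chain, would move the number beyond the scatter in this assay at all. Also open is whether phenyl in place of pyridin-3-yl reads the same way with fluoro on the other aromatic group, since the step shown here rests on one chloro pair.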